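The compounds below may be only part of what the source reports. "The series", "measured", "known", "first", "only" and "open" are said of these compounds alone.

Compound 1, `O=S(=O)(c1cccc2ccccc12)c1cn(C2CCCNC2)c2ccccc12`, gives 21 nM in an assay on HeLa cells for displacement of a labelled ligand from 5-hydroxytryptamine receptor 6 (Homo sapiens), with a stated time of 2 h; a higher number here means a weaker inhibitor, a lower number a stronger inhibitor. Compound 2, `CN1CCCC(n2cc(S(=O)(=O)c3cccc4ccccc34)c3ccccc32)C1`, gives 7.1 nM in this assay. Compound 3, `O=S(=O)(c1cccc(F)c1)c1cn(C2CCNC2)c2ccccc12`, gives 4.7 nM in this assay. Compound 4, `CN1CCC(n2cc(S(=O)(=O)c3cccc(F)c3)c3ccccc32)C1`, has not yet been measured in this assay.

Compound 2 differs from compound 1 by methyl in place of hydrogen on an amine nitrogen in a ring, and this change gives a 3.0-fold lower number from compound 1 to compound 2 (0.47 log units; beyond the scatter). The difference between the core of compound 1 and the core of compound 3 is not broken down here. Compound 3 and compound 2 lie within the scatter of each other, while compound 1 lies beyond the scatter of compound 3.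

Compound 4 differs from compound 3 by methyl in place of hydrogen on an amine nitrogen in a ring. This is the same kind of change as from compound 1 to compound 2, not the same: the amine nitrogen sits in a six-membered non-aromatic ring in the earlier pair and in a five-membered non-aromatic ring here. Given compound 1 to compound 2 shows a 3.0-fold lower number from compound 1 to compound 2 (0.47 log units; beyond the scatter), a step of a 2.4-fold lower number from compound 3 to compound 4 (0.37 log units; beyond the scatter) is expected here. Compound 4 is therefore estimated at 2 nM, between 0.8 nM and 5 nM.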

Compound 4, inhibition constant: 3.5 nM
Compound 4: middle estimate off by 1.8-fold (0.24 log units), on the low side; the measured number falls inside the stated range.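

Methyl in place of hydrogen on the amine nitrogen, here the change from pyrrolidin-3-yl to 1-methylpyrrolidin-3-yl, gives a 1.3-fold lower number from compound 3 to compound 4 (0.13 log units; within the scatter) in this assay, so on this core the step stays inside the scatter. Set beside the step on the six-membered ring, the two results cannot be told apart: the same change on two cores in this assay, a 3.0-fold lower number (0.47 log units; beyond the scatter) from compound 1 to compound 2 and a 1.3-fold lower number (0.13 log units; within the scatter) from compound 3 to compound 4, 2.2-fold (0.34 log units) apart, within the scatter of two such steps. This shows that the change can be carried between these two cores without a measurable difference in its size, but it does not show that the step is identical on both, and two pairs whose cores differ in more than one place establish no rule for the series.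

The compounds shown leave open whether the same result would hold with an ethyl group or a longer chain on that nitrogen. They also leave open how the five-membered and six-membered rings compare on an otherwise identical core, as no pair shown differs in the ring alone.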